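Benzyl ester series: furan and thiophene pyrimidinones at A2b

This account rests on a few compounds, and the source may have more. Where it says the series, first, only, none or still open, it means among the compounds named here.

Measured so far:
compound 1 `CC1=C(C(=O)OCc2ccccc2)C(c2ccco2)NC(=O)N1`: 887 nM
compound 2 `CC1=C(C(=O)OCc2ccccc2)C(c2cccs2)NC(=O)N1`: 1920 nM

Within the data shown here, in an assay on membranes from HEK293 cells for displacement of a labelled ligand from adenosine receptor A2b (Homo sapiens), read by scintillation counting, with a stated time of 30 min (on this read-out higher numbers stand for weaker inhibition and lower numbers for stronger inhibition), compound 1 gives 887 nM, the lowest of the two numbers so far; the nearest is compound 2, which in this assay gives 1920 nM. Among the measured compounds shown here, the single measured step, a 2.2-fold higher number from compound 1 to compound 2 (0.34 log units; beyond the scatter), concerns the aromatic ring on the saturated ring carbon and leaves the ester untouched.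

Compound 3 `CC1=C(C(=O)OC2CCC2)C(c2ccco2)NC(=O)N1` keeps the furan-2-yl of compound 1 and changes only the ester: cyclobutyl in place of benzyl on an oxygen next to a carbonyl group. For the measured compounds named here, no measured step bears on this position; the one step known says nothing about the ester, so the direction of the change cannot be read from the data. The estimate for compound 3 in this assay is therefore kept close to compound 1 with a wide range: 1500 nM, between 400 nM and 6000 nM, which as a step would mean a 1.7-fold higher number from compound 1 to compound 3 (0.23 log units; within the scatter), expected rather than known.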

Compound 3, inhibition constant: 95.1 nM
The estimate for compound 3 lay 16-fold (1.20 log units) above the measured number; the whole stated range lies above it.
By their numbers in this assay, from the lowest: compound 3; then compound 1; then compound 2.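

The ester position responds more strongly than the aromatic ring varied so far in this assay: cyclobutyl in place of benzyl on an oxygen next to a carbonyl group gives a 9.3-fold lower number from compound 1 to compound 3 (0.97 log units; beyond the scatter), a larger step than a 2.2-fold higher number from compound 1 to compound 2 (0.34 log units; beyond the scatter). With furan-2-yl held constant, this pair shows that the six-membered aromatic ring of benzyl is not needed for a lower number, and that a non-aromatic ring with fewer heavy atoms can take its place. No available evidence accounts for the size or direction of this step.

As far as these compounds go, it remains open whether the lower number is particular to cyclobutyl or extends to other esters, such as ethyl, isopropyl or cyclopentyl. The compounds shown also leave open whether thiophen-2-yl in place of furan-2-yl would shift the number in the same direction in a cyclobutyl ester.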